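Isopropyl Amide in Place of a Methyl Ester

A few compounds are considered here, and "the series" means these few. Any claim that something is new, unique, unknown or untested is made for them only; others in the source may bear on it.

Measured so far:
compound 1, `CC(=O)c1ccc(NC(=O)c2nc(-c3ccccc3)n(-c3ccc(S(N)(=O)=O)cc3)n2)cc1`, 64%
compound 2, `COC(=O)c1nc(-c2ccccc2)n(-c2ccc(S(N)(=O)=O)cc2)n1`, 61%

In a functional assay on the whole organism for inhibition, with Rattus norvegicus as the target, read by paw edema, with stated times of 30 min and 4 h, at a dose of 0.28 mmol/kg by the oral route (on this read-out lower numbers stand for less inhibition and higher numbers for more inhibition at the one dose given (going by the name of the read-out)), compound 1 gives 64%, and in this assay compound 2 gives 61%. Compound 2 thus holds the lower of the two numbers, but its nearest neighbour, compound 1, sits only a little higher, and the two cannot be told apart. For the measured compounds named here, the one step between them, a number 3 percentage points lower from compound 1 to compound 2 (within the scatter), comes from putting methoxy in place of (4-acetylphenyl)amino on the carbonyl carbon.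

Compound 3, `CC(C)NC(=O)c1nc(-c2ccccc2)n(-c2ccc(S(N)(=O)=O)cc2)n1`, is the next candidate. Against compound 2 it shows (isopropylamino in place of methoxy on a carbonyl carbon), on the carbonyl carbon whose other neighbour is an aromatic carbon. Going by the values given here, the only step that bears on it is the one from compound 1 to compound 2, which also exchanged a group on that carbonyl carbon and stayed within the scatter. Compound 3 is therefore expected to move by about a number 2 percentage points higher from compound 2 to compound 3 (within the scatter) in this assay, no step beyond the scatter. The estimated inhibition of compound 3 is 63%, in a range from 50% to 76%.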

Compound 3, a percentage reported as inhibition, in the whole organism at one dose (the size of the read-out at that dose, not a potency): 44%
Compound 3: the middle estimate sits 19 percentage points above what was measured, and the stated range ends above it.
By their numbers in this assay, from the lowest: compound 3; then compounds 2 and 1 (each within the scatter of the next).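

In this assay, for the compounds shown here, the carbonyl carbon proves sensitive to what it carries: isopropylamino in place of methoxy gives a number 17 percentage points lower from compound 2 to compound 3 (beyond the scatter), the first change in this short series to pass beyond the scatter. The amide link alone does not settle the outcome, since compound 1 and compound 3 are both amides, yet isopropyl in place of 4-acetylphenyl on the amide-type nitrogen gives a number 20 percentage points lower from compound 1 to compound 3 (beyond the scatter), while the ester compound 2 stays within the scatter of compound 1. What the group on that nitrogen does to produce this difference remains unexplained, as no supporting measurement is available.

The compounds shown leave open whether the acetyl group in compound 1 matters, or whether a plain phenylamino group on the same carbonyl carbon would serve as well. They also do not show how a methylamino group, a longer chain on the nitrogen, or a carboxylic acid in place of the ester would compare with compound 2 and compound 3.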